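Swapping an Ester Arm for a Thiophene Ring

The source may hold more compounds than are shown below. What is called first, only, known or untested is meant among the compounds shown, and "the series" means these compounds.

Measured so far:
Compound 1 `CCS[C@@H]1[C@H](SCC)[C@@H](Cn2cc(-c3ccccc3C(F)(F)F)nn2)O[C@H]1n1ccc(=O)[nH]c1=O`: 81100 nM
Compound 2 `CCOC(=O)c1cn(C[C@H]2O[C@@H](n3ccc(=O)[nH]c3=O)[C@H](SCC)[C@@H]2SCC)nn1`: >= 100000 nM
Compound 3 `CCS[C@@H]1[C@H](SCC)[C@@H](Cn2cc(COC(C)=O)nn2)O[C@H]1n1ccc(=O)[nH]c1=O`: >= 100000 nM

In a functional assay on LAC cells (Homo sapiens) for cytotoxicity, read by MTT assay, with a stated time of 72 h (a higher number here means that more compound is needed for the effect, a lower number that less compound is needed), compound 1 gives 81100 nM. For compound 2 the assay reports only a limit, >= 100000 nM. For compound 3 the assay likewise reports only a limit, >= 100000 nM. Compound 3 therefore stands at the edge of what this assay can resolve, a position it shares with one other compound (the limit of >= 100000 nM in this assay, at which 2 of the 3 values shown sit). The steps leading there are small: an at least 1.2-fold higher number from compound 1 to compound 2 (0.09 log units; that floor lies within the scatter) and an at least 1.2-fold higher number from compound 1 to compound 3 (0.09 log units; that floor lies within the scatter) are both only floors that lie within the scatter, and a step that the two limits leave unreadable from compound 2 to compound 3 cannot be read from two limits.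

Compound 4 `CCS[C@@H]1[C@H](SCC)[C@@H](Cn2cc(-c3cccs3)nn2)O[C@H]1n1ccc(=O)[nH]c1=O` differs from compound 3 in one place: thiophen-2-yl in place of acetoxymethyl on an aromatic carbon. Within the data shown here, the only measured step that bears on this kind of change is the one from an aromatic ring to the ester arm, an at least 1.2-fold higher number from compound 1 to compound 3 (0.09 log units; that floor lies within the scatter), which was too small to read beyond the scatter. Moving back to a ring is therefore expected to change little, giving a step of an at least 1.1-fold lower number from compound 3 to compound 4 (0.07 log units; that floor lies within the scatter). Compound 4 is estimated at 85000 nM, with a range from 40000 nM to 160000 nM, and a fair chance that this assay again returns only a limit.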

Compound 4, half-maximal effective concentration: 86500 nM
The estimate for compound 4 lay 1.0-fold (0.01 log units) below the measured number; measured number inside the range.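

In this assay compound 4 is the second compound shown, after compound 1, to return a number rather than a limit, so both compounds with an aromatic ring on this carbon give a readable value, while the ethoxycarbonyl and acetoxymethyl compounds do not. This contrast remains weak, with an at least 1.1-fold lower number from compound 3 to compound 4 (0.06 log units; that floor lies within the scatter) and an at least 1.1-fold lower number from compound 2 to compound 4 (0.06 log units; that floor lies within the scatter), because compound 2 and compound 3 give only limits, which leaves floors and not sizes for these steps: the limit of >= 100000 nM in this assay, at which 2 of the 4 values shown sit.
Replacing 2-(trifluoromethyl)phenyl with thiophen-2-yl exchanges a ring bearing a large substituent for a five-membered aromatic ring with 1 hetero atom, yet the result is a 1.1-fold higher number from compound 1 to compound 4 (0.03 log units; within the scatter), so these two rings cannot be told apart here.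

It remains open whether any group on this carbon can move the number beyond the scatter, and no step shown so far does so. An amine, a carboxylic acid or a simple pyridine ring at this place would test whether the readable values belong to aromatic rings alone or extend to quite different groups.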